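The compounds below may be only part of what the source reports. "The series", "measured", "known", "first", "only" and "open" are said of these compounds alone.

Series notes, a functional assay on KG-1 cells (Homo sapiens) for antiproliferative activity; on this read-out higher numbers stand for an effect only at larger amounts of compound and lower numbers for an effect already at smaller amounts.

Compound 1 `NC(=O)c1cc(Cl)c2c(Cl)c(C#CCO)n([C@H]3CCCNC3)c2n1` gives 301 nM in this assay. Compound 2 `CC(C)(C#N)CC#Cc1c(Cl)c2c(Cl)cc(C(N)=O)nc2n1[C@H]1CCCNC1` gives 113 nM, the lowest of the two single numbers, with compound 1 the nearest. Compound 3 `NC(=O)c1cc(Cl)c2c(Cl)c(C#CC3CNCCO3)n([C@H]3CCCNC3)c2n1` has two entries, 365 nM; 197 nM (2 entries), and the several entries of compound 3 in this assay, 365 nM; 197 nM (2 entries) shows how far repeats of one compound can sit apart in this assay.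

Among the measured compounds shown here, the one measured step, a 2.7-fold lower number from compound 1 to compound 2 (0.43 log units; beyond the scatter), came with 1-cyano-1-methylethyl in place of hydroxy on a saturated chain carbon bound to a triple-bonded carbon.

Compound 4 `CC(C)(O)C#Cc1c(Cl)c2c(Cl)cc(C(N)=O)nc2n1[C@H]1CCCNC1` has not yet been measured in this assay. The change from compound 2 is 1-hydroxy-1-methylethyl in place of 2-cyano-2-methylpropyl on a triple-bonded carbon. This largely runs the measured step backwards: the nitrile-bearing arm goes out and a hydroxy-bearing group comes in, while the chain is shortened so that the hydroxy sits closer to the alkyne than in compound 1. The step from compound 1 to compound 2 is the only one that bears on it, and it was modest, so a modest rise in the number is expected, roughly back toward compound 1, as a 2.2-fold higher number from compound 2 to compound 4 (0.34 log units; beyond the scatter). Compound 4 is therefore estimated at 250 nM, with a range of 110 nM to 560 nM.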

Compound 4, half-maximal effective concentration: 302 nM
For compound 4 the middle estimate is 1.2-fold (0.08 log units) below the measured one, within the range that was stated.
By their numbers in this assay, from the lowest: compound 2; then compounds 1 and 4 (each within the scatter of the next).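

On the triple-bonded carbon, this assay now gives a second comparison of 2-cyano-2-methylpropyl with a hydroxy-bearing group, and it agrees with the first: a 2.7-fold higher number from compound 2 to compound 4 (0.43 log units; beyond the scatter). The two hydroxy-bearing groups, by contrast, cannot be told apart, which is new for this position: a 1.0-fold higher number from compound 1 to compound 4 (0.00 log units; within the scatter). Among compounds 1, 2 and 4, the number therefore separates the nitrile-bearing group from both hydroxy-bearing groups, and repeats of a single compound give a yardstick for such gaps: the several entries of compound 3 in this assay, 365 nM; 197 nM (2 entries)

Still open, going by these compounds, is whether the lower number of compound 2 goes with the nitrile itself or with the longer branched chain that carries it. A plain hydrocarbon chain of the same shape, or a nitrile on a shorter chain, would separate the two readings, and an amine in the same place would test a different kind of group.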